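Swapping the halogenated ring in a naphthyloxy hydrazone series

The source may hold more compounds than are shown below. What is called first, only, known or untested is meant among the compounds shown, and "the series" means these compounds.

Of the compounds shown here, three sharing one core have been tested in an ADME assay on MT4 cells (Homo sapiens) for cytotoxicity, read by MTT assay, with a stated time of 4 days; on this read-out lower numbers stand for higher toxicity in this test and higher numbers for lower toxicity in this test. Compound 1 `O=C(COc1cccc2ccccc12)N/N=C/c1ccccc1Br` gives 11.4 ug/mL in this assay. Compound 2 `COc1cc(/C=N/NC(=O)COc2cccc3ccccc23)cc(OC)c1O` gives 16.3 ug/mL, and compound 3 `C/C(=N\NC(=O)COc1cccc2ccccc12)c1cccc([N+](=O)[O-])c1` gives 12.1 ug/mL. The three numbers sit close together: the gap between compound 1 and compound 3, and the gap between compound 1 and compound 2, both lie within the usual scatter of repeated measurements, so none of the three can be called more or less toxic than another on this evidence.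

Compound 4 `O=C(COc1cccc2ccccc12)N/N=C/c1cccc(Cl)c1` has not yet been measured in this assay. It differs from compound 1 in one place: 3-chlorophenyl in place of 2-bromophenyl on a carbon with a double bond to nitrogen. Going by the values given here, no measured pair in this small set shows what such a change does, so the only guide is that the halogenated ring is exchanged for another of the same size and the core is untouched. The step from compound 1 to compound 4 is therefore expected to be small, a 1.1-fold higher number from compound 1 to compound 4 (0.02 log units; within the scatter), in no clear direction and not beyond the scatter. On that basis compound 4 is estimated at 12 ug/mL, with a likely range from 6 ug/mL to 24 ug/mL.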

Compound 4, half-maximal cytotoxic concentration: 89.9 ug/mL
Estimate against measurement, compound 4: 7.5-fold (0.87 log units) below; measured number outside the range, above it.
By their numbers in this assay, from the lowest: compounds 1, 3 and 2 (each within the scatter of the next); then compound 4.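

In this assay, this one exchange on a carbon with a double bond to nitrogen gives a clear separation, a 7.9-fold higher number from compound 1 to compound 4 (0.90 log units; beyond the scatter), so compound 4 is the less toxic of the pair in this test. The earlier compounds shown here gave no sign that this place could move the number so far, yet here the entering and leaving groups have the same heavy-atom count and the same kind of ring, and differ only in the halogen and in the number in the group's name. Nothing available here explains the step.

On these data alone, the swap changes two things at once, so it remains open whether the halogen or its ring position accounts for the step. A 3-bromophenyl or a 2-chlorophenyl group at this place, on the same core, would separate the two.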